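Swapping the saturated ring on the shared core

The compounds below may be only part of what the source reports. "The series", "measured", "known", "first", "only" and "open" are said of these compounds alone.

Of the compounds shown here, three with the same core have been tested in a functional assay on PC-3 cells (Homo sapiens) for antiproliferative activity, read by MTT assay, with a stated time of 72 h; on this read-out higher numbers stand for weaker inhibition and lower numbers for stronger inhibition. Compound 1 `C=C(C)C(=O)Nc1cc2c(N3CCc4ccccc43)ncnc2cc1O[C@@H]1CCOC1` gives 4910 nM in this assay. Compound 2 `C/C=C/C(=O)Nc1cc2c(N3CCc4ccccc43)ncnc2cc1O[C@@H]1CCOC1` gives 5220 nM in this assay, which places it second highest of the three numbers, with compound 1 nearest and compound 3 furthest. Compound 3 `CCC/C=C/C(=O)Nc1cc2c(N3CCc4ccccc43)ncnc2cc1O[C@@H]1CCOC1` gives 9230 nM in this assay. The steps among them are small: a 1.1-fold higher number from compound 1 to compound 2 (0.03 log units; within the scatter), a 1.9-fold higher number from compound 1 to compound 3 (0.27 log units; within the scatter) and a 1.8-fold higher number from compound 2 to compound 3 (0.25 log units; within the scatter), all inside the usual spread of repeat measurements, and all of them concern the chain on the carbonyl carbon.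

Compound 4 `C/C=C/C(=O)Nc1cc2c(N3CCCc4ccccc43)ncnc2cc1O[C@@H]1CCOC1` differs from compound 2 elsewhere: 1,2,3,4-tetrahydroquinolin-1-yl in place of 2,3-dihydro-1H-indol-1-yl on an aromatic carbon. Going by the values given here, no measured step touches this position, so the earlier numbers give no direction for it. The three measured compounds span only a narrow band, which suggests the core tolerates small edits without large shifts, but that evidence comes from a different part of the molecule. The expected step is therefore a 1.1-fold higher number from compound 2 to compound 4 (0.06 log units; within the scatter), with a wide allowance for the unknown. In this assay compound 4 is estimated at 6000 nM, within a range from 2000 nM to 18000 nM.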

Compound 4, half-maximal inhibitory concentration: 9350 nM
The estimate for compound 4 lay 1.6-fold (0.19 log units) below the measured number; the range from low to high includes it.
By their numbers in this assay, from the lowest: compounds 1, 2, 3 and 4 (each within the scatter of the next).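

Going by these compounds alone, the first reading at this position shows that, in this assay, putting 1,2,3,4-tetrahydroquinolin-1-yl in place of 2,3-dihydro-1H-indol-1-yl gives a 1.8-fold higher number from compound 2 to compound 4 (0.25 log units; within the scatter). A six-membered non-aromatic ring can therefore stand where the five-membered one stood without moving the number outside the normal spread of repeat measurements, and this step is about the same size as the one along the chain on the carbonyl carbon, a 1.8-fold higher number from compound 2 to compound 3 (0.25 log units; within the scatter). No measurement shown here explains the number for compound 4 or says what the extra ring member does.

As far as these compounds go, two ring groups are a narrow sample of this position, so it remains open whether a larger change, such as a simple amine like piperidine or morpholine with no fused aromatic ring, or a seven-membered ring fused to the same aromatic ring, would give a step beyond that spread. From the compounds shown here alone, it is also open whether 1,2,3,4-tetrahydroquinolin-1-yl would behave the same way alongside the 1-methylethenyl or pent-1-en-1-yl chains carried by compound 1 and compound 3.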